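The source may report more compounds than this note shows. Statements on the series, on what has been measured and on what is new or still open speak of the compounds shown alone.

In an ADME assay for pharmacokinetics, read by LC-MS, in phosphate buffer, with a stated time of 120 min, at pH 7.4, tested at 1 uM, in the presence of a further agent that is not named here (on this read-out higher numbers stand for a longer-lived compound and lower numbers for a shorter-lived compound), compound 1 `C=C(C)C(=O)Nc1ccccc1` gives > 8.53 h, which is a limit of the assay and not a number. Its true half-life is therefore unknown. Two related compounds gave numbers: compound 2 `O=C(/C=C/C(F)F)Nc1ccccc1` gives 0.733 h, and compound 3 `CN(C)C/C=C/C(=O)Nc1ccccc1` gives 1.93 h. Going by the values given here, the only measured step is a 2.6-fold higher number from compound 2 to compound 3 (0.42 log units; beyond the scatter). It is modest, though beyond the scatter, and it concerns other groups than the one changed next.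

Compound 4 `C=C(CO)C(=O)Nc1ccccc1` differs from compound 1 by hydroxy in place of hydrogen on a saturated chain carbon bound to a double-bonded chain carbon, with hydroxy in place of hydrogen on a saturated chain carbon bound to a double-bonded chain carbon, so that methyl becomes hydroxymethyl. Among the compounds with values here, no measured step makes this change, so the evidence bears on it only loosely. With compound 3 at 1.93 h as the longest measured number, a modest shortening in this assay seems the likeliest outcome. The expected change is an at least 2.1-fold lower number from compound 1 to compound 4 (0.32 log units; beyond the scatter), and its size is uncertain. The estimated half-life of compound 4 is 4 h, with an expected range of 1.5 h to 10 h.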

Compound 4, half-life: > 8.53 h
Compound 4: only a limit was reported (the forecaster's own chance of this, stated with the estimate: 20%); at least 2.1-fold (0.32 log units) between middle value and limit.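

Compound 1 and compound 4 both sit at a limit of the assay and not at a number, so the step between them cannot be read: the limit of > 8.53 h in this assay, at which 2 of the 4 values shown sit.

The compounds shown leave open how long either half-life truly is, and whether hydroxymethyl in place of methyl changes it at all.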